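Methylcarbamoyl replaces cyclopropyl on the aromatic ring

The source may hold more compounds than are shown below. What is called first, only, known or untested is meant among the compounds shown, and "the series" means these compounds.

Of the compounds shown here, three built on one shared core have been measured in a functional assay on the whole organism for inhibition, with Rattus norvegicus as the target; on this read-out higher numbers stand for an effect only at larger amounts of compound and lower numbers for an effect already at smaller amounts. Compound 1 `CC1CC/C(=N\Nc2ccc([N+](=O)[O-])cc2)c2ncc(C(=O)O)c(=O)n21` gives 0.8 umol/kg, compound 2 `CC1CC/C(=N\Nc2ccc(C(=O)O)cc2)c2ncc(C(=O)O)c(=O)n21` gives 7.6 umol/kg, and compound 3 `CC1CC/C(=N\Nc2ccc(C3CC3)cc2)c2ncc(C(=O)O)c(=O)n21` gives 41.1 umol/kg. Compound 3 therefore stands with the highest number of the three, needing the largest dose: it lies a 5.4-fold higher number from compound 2 to compound 3 (0.73 log units; beyond the scatter) and a 51-fold higher number from compound 1 to compound 3 (1.71 log units; beyond the scatter). Going by the values given here, all three differ only in the single group attached to the six-membered aromatic ring of carbon only.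

Compound 4 `CNC(=O)c1ccc(N/N=C2\CCC(C)n3c2ncc(C(=O)O)c3=O)cc1` varies that same position once more: methylcarbamoyl in place of cyclopropyl on an aromatic carbon. Among the compounds with values here, no measured step involves methylcarbamoyl itself. Within the data shown here, the steps that bear on the change are the two that lead into compound 3, a 51-fold higher number from compound 1 to compound 3 (1.71 log units; beyond the scatter) and a 5.4-fold higher number from compound 2 to compound 3 (0.73 log units; beyond the scatter), both of which moved the number upward when cyclopropyl entered; removing cyclopropyl again should move it back down. Of the measured groups, carboxy in compound 2 is the nearest relative of methylcarbamoyl, both bringing a hydrogen-bond donor and acceptor that cyclopropyl lacks, so the carboxy step read in reverse is the better guide.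

Compound 4 is thus expected to show a 4.1-fold lower number from compound 3 to compound 4 (0.61 log units; beyond the scatter) in this assay. The estimate for compound 4 is 10 umol/kg, with a plausible range from 3 umol/kg to 35 umol/kg.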

Compound 4, dose for 50% inhibition: 9.6 umol/kg
Compound 4: the middle estimate sits 1.0-fold (0.02 log units) above what was measured; measured number inside the range.
By their numbers in this assay, from the lowest: compound 1; then compounds 2 and 4 (each within the scatter of the next); then compound 3.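

In this assay, the swap of cyclopropyl for methylcarbamoyl gives a 4.3-fold lower number from compound 3 to compound 4 (0.63 log units; beyond the scatter), so this position tolerates a group with one hydrogen-bond donor and one hydrogen-bond acceptor far better than it tolerates the small carbon ring. Replacing hydroxy with methylamino on the carbonyl carbon gives a 1.3-fold higher number from compound 2 to compound 4 (0.10 log units; within the scatter), which lies within the scatter, so the amide and the carboxy group cannot be told apart here, while the nitro group of compound 1 keeps a clear lead, as a 12-fold higher number from compound 1 to compound 4 (1.08 log units; beyond the scatter) shows. Nothing in the data on hand explains why these groups rank as they do. 

As far as these compounds go, it remains open whether the simple carboxamide, which has no methyl on its nitrogen, or the dimethylamide, which has no amide hydrogen, would stay level with compound 4 or come closer to compound 1. A nitrile, a sulfonamide or a longer chain on the amide nitrogen, such as ethyl or propyl, would also show whether the nitro group's lead can be matched by another group at this position.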